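The source may report more compounds than this note shows. Statements on the series, on what has been measured and on what is new or still open speak of the compounds shown alone.

Compound 1 `C=C(Br)C(=O)Nc1cccc(/C=C2\SC(=O)N(Cc3ccc(Cl)cc3)C2=O)c1` is measured in a functional assay on L1210 cells (Mus musculus) for cytotoxicity, read by cell counting, with a stated time of 2 days (a lower number here means a stronger inhibitor, a higher number a weaker inhibitor), where compound 1 gives 940 nM. Compound 2 `C=C(Br)C(=O)Nc1cccc(/C=C2\SC(=O)N(Cc3ccc(C)cc3)C2=O)c1` gives 600 nM and compound 3 `C=C(Br)C(=O)Nc1cccc(/C=C2\SC(=O)N(Cc3ccc(F)cc3)C2=O)c1` gives 680 nM; compound 1 thus carries the highest of the three numbers, but the steps of a 1.6-fold lower number from compound 1 to compound 2 (0.19 log units; within the scatter) and a 1.4-fold lower number from compound 1 to compound 3 (0.14 log units; within the scatter) both stay within the scatter, as does a 1.1-fold higher number from compound 2 to compound 3 (0.05 log units; within the scatter). Compound 4 `Nc1cccc(/C=C2\SC(=O)N(Cc3ccc(Cl)cc3)C2=O)c1` differs from compound 1 at another place: hydrogen in place of (1-bromoethenyl)carbonyl on a nitrogen on an aromatic ring. None of the three measured steps touches this nitrogen on an aromatic ring; each varied only the aromatic carbon substituent, so they give no guide to the size of this step in this assay. The change removes a group of five heavy atoms with two double bonds outside aromatic rings, and a larger step than any seen so far is plausible in either direction. The author expects the number for compound 4 to be higher, at 4000 nM, within 700 nM to 25000 nM, meaning an estimated step of a 4.3-fold higher number from compound 1 to compound 4 (0.63 log units; beyond the scatter).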

Compound 4, half-maximal inhibitory concentration: 218000 nM
Beside the measured number, compound 4's estimate is 55-fold (1.74 log units) below it; the measured number lies above the stated range.
By their numbers in this assay, from the lowest: compounds 2, 3 and 1 (each within the scatter of the next); then compound 4.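

In this assay, the (1-bromoethenyl)carbonyl on the nitrogen on an aromatic ring proves to matter far more than the aromatic carbon substituent: its replacement by hydrogen gives a 230-fold higher number from compound 1 to compound 4 (2.37 log units; beyond the scatter), whereas the steps among compounds 1, 2 and 3 all stayed within the scatter. Nothing available explains the size of this step. The compounds shown leave open which part of the lost group carries the difference, since a plain acetyl or an acryloyl without the bromine on this nitrogen would separate its parts. They also leave open whether the step is as large with methyl or fluoro on the aromatic carbon.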